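Cyclohexyl on the ring nitrogen of compound 2

The source may hold more compounds than are shown below. What is called first, only, known or untested is meant among the compounds shown, and "the series" means these compounds.

Compound 1 `C/C(=N\NC(N)=O)c1ccc2[nH]c(-c3ccccc3)nc2c1` gives > 100000 nM as a limit
Compound 2 `C/C(=N\NC(N)=O)c1ccc2[nH]c(-c3ccc(C(F)(F)F)cc3)nc2c1` gives > 100000 nM as a limit

In an ADME assay on MDBK cells (Bos taurus) for cytotoxicity, read by MTT assay, with a stated time of 96 h (a higher number here means that more compound is tolerated, a lower number that less compound is tolerated), compound 2 stands only at > 100000 nM as a limit and has no number. Going by the values given here, the only measured step is a step that the two limits leave unreadable from compound 1 to compound 2 and so sets no size for what follows. The change to compound 3 `C/C(=N\NC(N)=O)c1ccc2c(c1)nc(-c1ccc(C(F)(F)F)cc1)n2C1CCCCC1` is cyclohexyl in place of hydrogen on an aromatic nitrogen and puts cyclohexyl in place of hydrogen on an aromatic nitrogen, next to the ring atom that bears a 4-(trifluoromethyl)phenyl group. Among the compounds with values here, no measured compound carries a group on that nitrogen, and the only evidence is the limit of > 100000 nM in this assay, at which 2 of the 2 values shown sit, which gives no size either. A shift toward less compound tolerated is expected, though another limit reading remains quite possible. The expected step is an at least 1.6-fold lower number from compound 2 to compound 3 (0.22 log units; that floor lies within the scatter) on this estimate. The estimate for compound 3 is 60000 nM with an expected range from 18000 nM to 100000 nM in this assay.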

Compound 3, half-maximal cytotoxic concentration: > 100000 nM
Compound 3: only a limit was reported; the forecaster's own chance of this, stated with the estimate: 45%; middle value at least 1.6-fold (0.22 log units) from the limit.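

In this assay, going by these compounds alone, compound 3 gives > 100000 nM, a limit, and compound 2 also stands at a limit, so no step between them can be read. The compounds shown leave open whether cyclohexyl on the aromatic nitrogen changes the tolerated concentration at all.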